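Isobutyl in place of methoxyphenoxy: expected permeability

The compounds below may be only part of what the source reports. "The series", "measured", "known", "first", "only" and "open" are said of these compounds alone.

Compound 1, `COc1ccc(Oc2ccc3c(NCCCNCc4cc(F)ccc4OC)ccnc3c2)cc1`: 317 10^-6 cm/s
Compound 2, `COc1cccc(Oc2ccc3c(NCCCNCc4cc(F)ccc4OC)ccnc3c2)c1`: 317 10^-6 cm/s

Both values come from an ADME assay for permeability, using PAMPA, with a stated time of 30 min, at pH 7.4; on this read-out higher numbers stand for higher permeability and lower numbers for lower permeability. Within the data shown here, the only measured step, no change at the digits printed from compound 1 to compound 2 (within the scatter), exchanged a 4-methoxyphenyl for a 3-methoxyphenyl and left the read-out where it was, so compound 2 stands level with compound 1 and neither can be called the more permeable of the two. Compound 3, `COc1ccc(F)cc1CNCCCNc1ccnc2cc(CC(C)C)ccc12`, differs from compound 2 in one place: isobutyl in place of 3-methoxyphenoxy on an aromatic carbon. The measured step only rearranged the same group on the oxygen and does not touch the exchange at hand, so it offers little direct guidance; what it does show is a read-out that did not move. Among the measured compounds shown here, with no step pointing downward, the expected step of a 1.1-fold lower number from compound 2 to compound 3 (0.02 log units; within the scatter) is none beyond the scatter. Compound 3 is therefore estimated at 300 10^-6 cm/s, with a likely range from 150 10^-6 cm/s to 500 10^-6 cm/s.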

Compound 3, apparent permeability: 23 10^-6 cm/s
Estimate against measurement, compound 3: 13-fold (1.12 log units) above; measured number outside the range, below it.
By their numbers in this assay, from the lowest: compound 3; then compounds 1 and 2 (each within the scatter of the next).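

In this assay, the position on the aromatic carbon now shows a large step: isobutyl in place of 3-methoxyphenoxy gives a 14-fold lower number from compound 2 to compound 3 (1.14 log units; beyond the scatter) and isobutyl in place of 4-methoxyphenoxy gives a 14-fold lower number from compound 1 to compound 3 (1.14 log units; beyond the scatter) with the same size on both routes. Among these compounds, compounds 1 and 2 showed only that moving the methoxy group around the phenoxy ring left the number level, whereas replacing the whole group, with its aromatic ring and two oxygens, does not. Nothing available explains why the number falls with this exchange.

The compounds shown leave open which part of the departing group matters, the ring, the linking oxygen or the methoxy group. An unsubstituted phenoxy, a lone methoxy or an amine at this position could begin to separate these parts.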